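A benzodioxin swap measured once, now made a second time

This account rests on a few compounds, and the source may have more. Where it says the series, first, only, none or still open, it means among the compounds named here.

Three compounds have been measured in a functional assay on WM 266-4 cells (Homo sapiens) for inhibition, read by MTT assay, with a stated time of 24 h; on this read-out higher numbers stand for weaker inhibition of growth and lower numbers for stronger inhibition of growth:

Compound 1, `COc1ccc(C2=NN(C(=O)C3COc4ccccc4O3)C(c3ccc(OC)cc3)C2)cc1`: 11000 nM
Compound 2, `O=C(c1ccc2c(c1)OCCO2)N1N=C(c2ccccc2)CC1c1ccc(F)cc1`: 5210 nM
Compound 3, `COc1ccc(C2=NN(C(=O)c3ccc4c(c3)OCCO4)C(c3ccc(OC)cc3)C2)cc1`: 9890 nM

Compound 3 and compound 1 differ in one place, (2,3-dihydro-1,4-benzodioxin-2-yl in place of 2,3-dihydro-1,4-benzodioxin-6-yl on a carbonyl carbon). The step of a 1.1-fold higher number from compound 3 to compound 1 (0.05 log units; within the scatter) lies within the scatter, so the two values cannot be told apart. Compound 2 shares its core with neither pair in a way that is broken down here; its value and that of compound 3 sit within the scatter of each other, while the gap to compound 1 lies beyond it.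

Compound 4, `O=C(C1COc2ccccc2O1)N1N=C(c2ccccc2)CC1c1ccc(F)cc1`, is not yet measured. It arises from compound 2 by the same change, (2,3-dihydro-1,4-benzodioxin-2-yl in place of 2,3-dihydro-1,4-benzodioxin-6-yl on a carbonyl carbon), with the place described in the same words. Within the data shown here, since the one earlier instance, a 1.1-fold higher number from compound 3 to compound 1 (0.05 log units; within the scatter), left the number essentially where it was, the step from compound 2 to compound 4 in this assay is expected to be a 1.1-fold higher number from compound 2 to compound 4 (0.02 log units; within the scatter), again within the scatter. Compound 4 is therefore estimated at 5500 nM, with a likely range from 2600 nM to 12000 nM.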

Compound 4, concentration for 50% growth inhibition: 3270 nM
For compound 4 the middle estimate is 1.7-fold (0.23 log units) above the measured one; measured number inside the range.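

In this assay, the second instance of the swap gives a 1.6-fold lower number from compound 2 to compound 4 (0.20 log units; within the scatter), so on this core too the two benzodioxin attachments cannot be told apart. Set beside the first instance, the change shows no detectable dependence on which of the two cores carries it: the same change on two cores in this assay, a 1.1-fold higher number (0.05 log units; within the scatter) from compound 3 to compound 1 and a 1.6-fold lower number (0.20 log units; within the scatter) from compound 2 to compound 4, 1.8-fold (0.25 log units) apart, within the scatter of two such steps. This shows that both cores agree in leaving the number within the scatter, but it does not show that the swap would be equally silent on other cores, and two instances give no general rule for the series.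

From the compounds shown here alone, all four compounds carry one of these two benzodioxin groups on the carbonyl carbon, so it remains open how the number would respond to a different group there, such as a longer chain, an amine or a carboxylic acid. Going by these compounds, it also remains open whether the swap would stay within the scatter on a core bearing an amine or a carboxylic acid.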